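This account rests on a few compounds, and the source may have more. Where it says the series, first, only, none or still open, it means among the compounds named here.

Compound 1 `COc1ccc(C(=O)c2sc(NC(C)C)c(C#N)c2N)cc1` is a ketone built on the shared core, and in an assay for inhibition of Maternal embryonic leucine zipper kinase (Homo sapiens), read by ADP-Glo, with a stated time of 0.5 h (on this read-out lower numbers stand for stronger inhibition and higher numbers for weaker inhibition), compound 1 gives 4130 nM. Compound 2 `CC(=O)c1sc(NC(C)C)c(C#N)c1N`, which carries a methyl ketone on the same core, reaches only a limit of this assay; in this assay compound 2 gives > 5000 nM, a limit rather than a number. Within the data shown here, compound 1 therefore holds the only measured value among the two, while the other entry stands at the limit of > 5000 nM in this assay, at which 1 of the 2 values shown sits. Compound 3 `COc1ccc(C(=O)c2sc(NC(C)C)c(C#N)c2N)cc1OC` differs from compound 1 by methoxy in place of hydrogen on an aromatic carbon, a methoxy in place of hydrogen on an aromatic carbon. Among the measured compounds shown here, no measured pair in this set shows what such a change does, so the step from compound 1 to compound 3 is expected to fall within the scatter, with no preferred direction, and the expected step is a 1.2-fold lower number from compound 1 to compound 3 (0.07 log units; within the scatter). On that basis compound 3 is estimated at 3500 nM in this assay, within a range from 1200 nM to 10000 nM.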

Compound 3, half-maximal inhibitory concentration: 1770 nM
Compound 3: middle estimate off by 2.0-fold (0.30 log units), on the high side; measured number inside the range.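

Methoxy in place of hydrogen on an aromatic carbon, ortho to a methoxy group and meta to a large group, gives a 2.3-fold lower number from compound 1 to compound 3 (0.37 log units; beyond the scatter) in this assay. Among these compounds, this shows that the number at this position of the six-membered aromatic ring responds to the added group, modestly but beyond the scatter, whereas the earlier compounds offered one number and one limit and no step. Nothing measured here accounts for the change in number.

The compounds shown leave open whether a hydroxyl, a fluorine or an ethoxy at this same place would move the number in the same direction. They also leave open whether the step depends on the methoxy group already present in compound 1, and how an amine or a carboxylic acid here would read.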